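The source may hold more compounds than are shown below. What is called first, only, known or untested is meant among the compounds shown, and "the series" means these compounds.

Measured in a functional assay on HeLa cells (Homo sapiens) for antiproliferative activity, read by MTT assay, with a stated time of 24 h; a lower number here means a stronger inhibitor, a higher number a weaker inhibitor:
- Compound 1 `Clc1cccc(CSc2nnc(-c3ccc4c(c3)OCCO4)n2-c2ccccc2)c1`: 15000 nM
- Compound 2 `COc1cccc(CSc2nnc(-c3ccc4c(c3)OCCO4)n2-c2ccccc2)c1`: > 100000 nM, a limit of the assay
- Compound 3 `Cc1ccc(CSc2nnc(-c3ccc4c(c3)OCCO4)n2-c2ccccc2)cc1`: 49700 nM

Of the two actual numbers, compound 3 has the higher, 49700 nM. Compound 4 `Fc1cccc(F)c1CSc1nnc(-c2ccc3c(c2)OCCO3)n1-c1ccccc1` carries 2,6-difluorophenyl in place of 4-methylphenyl on a saturated chain carbon bound to a sulfur. The closest measured swaps at this place are a 3.3-fold higher number from compound 1 to compound 3 (0.52 log units; beyond the scatter) and an at least 2.0-fold lower number from compound 2 to compound 3 (0.30 log units; that floor lies within the scatter). Only compound 1, with its 3-chlorophenyl, carries a halogen, so the new halogen-bearing group may lean toward a lower number, on thin support. In this assay, the expected step is therefore small, a 1.7-fold lower number from compound 3 to compound 4 (0.22 log units; within the scatter), and probably within the scatter. For compound 4, the estimated value is 30000 nM, with an expected range of 10000 nM to 90000 nM.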

Compound 4, half-maximal inhibitory concentration: 35200 nM
For compound 4 the middle estimate is 1.2-fold (0.07 log units) below the measured one; the measured number falls inside the stated range.
By their numbers in this assay, from the lowest: compound 1; then compounds 4 and 3 (each within the scatter of the next). At a limit, above all of these: compound 2.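

In this assay, the second halogen-bearing group at this place does not match 3-chlorophenyl, giving a 2.3-fold higher number from compound 1 to compound 4 (0.37 log units; beyond the scatter) and so showing that a halogen on this ring does not by itself set the level of compound 1. It also separates from 3-methoxyphenyl, with an at least 2.8-fold lower number from compound 2 to compound 4 (0.45 log units; beyond the scatter), yet 4-methylphenyl and 2,6-difluorophenyl cannot be told apart, with a 1.4-fold lower number from compound 3 to compound 4 (0.15 log units; within the scatter). The value of compound 2 is a limit of the assay: the limit of > 100000 nM in this assay, at which 1 of the 4 values shown sits.

As far as these compounds go, what an amine or a carboxylic acid on this ring, or a longer chain at this place, would do remains open.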